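Removing the butyl chain: expected tolerance on Vero cells

The source may report more compounds than this note shows. Statements on the series, on what has been measured and on what is new or still open speak of the compounds shown alone.

Measured compounds in an ADME assay on Vero cells (Chlorocebus sabaeus) for cytotoxicity, read by microscopy, with a stated time of 6 days; a lower number here means that less compound is tolerated, a higher number that more compound is tolerated:
- compound 1, `CCCCCCCCNc1nccnc1C(=O)NCc1ccccc1`, gives > 100000 nM, which is a limit of the assay and not a number.
- compound 2, `CCCCCCNc1cnc(C(=O)NCc2ccccc2)cn1`, gives >= 100000 nM, also a limit of the assay.
- compound 3, `CCCCNc1cnc(C(=O)NCc2ccccc2)cn1`, gives > 100000 nM, again a limit of the assay.

Compound 1 therefore stands only at a limit in this assay, and the two further values shown are limits as well, so none of the three compounds can be placed higher or lower than another. Among the compounds with values here, the single comparable step in this set, a step that the two limits leave unreadable from compound 2 to compound 3, cannot be read for the same reason.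

The unmeasured compound 4, `CCCCNc1nccnc1C(=O)NCc1ccccc1`, differs from compound 1 by hydrogen in place of butyl on a saturated chain carbon, four bonds along the chain from a nitrogen on an aromatic ring. The measured step that resembles this change most is the shortening of the chain in a step that the two limits leave unreadable from compound 2 to compound 3, and it gave no readable size. Within the data shown here, since every value so far sits at a limit, as the limit of > 100000 nM in this assay, at which 2 of the 3 values shown sit, and the limit of >= 100000 nM in this assay, at which 1 of the 3 values shown sits, show, the step of a number no higher from compound 1 to compound 4 (the limit leaves the size open) is expected to be none beyond the scatter. Compound 4 is thus estimated at 100000 nM, with a range from 50000 nM to 200000 nM, and most probably the assay will again report only a limit.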

Compound 4, minimum cytotoxic concentration: > 100000 nM
Compound 4 gave a limit, no number (the forecaster's own chance of this, stated with the estimate: 85%); the middle value sits exactly at the limit.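

Compound 1 and compound 4 each stand only at a limit of the assay in this assay, so the step between them cannot be read and neither can be placed higher or lower than the other. The compounds shown leave open the concentration at which any of them becomes toxic to the cells, and whether changing the chain alters that concentration at all.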